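The compounds below may be only part of what the source reports. "The series", "measured", "known", "first", "only" and "open" are said of these compounds alone.

Compound 1, `CC(C(=O)NCc1ccc(C(C)(C)C)nc1N1CCCC1)c1ccc(NS(C)(=O)=O)c(F)c1`: 1.2 nM
Compound 2, `CC(C(=O)NCc1ccc(C(C)(C)C)nc1N1CCCCCC1)c1ccc(NS(C)(=O)=O)c(F)c1`: 0.9 nM
Compound 3, `CCCOc1nc(C(C)(C)C)ccc1CNC(=O)C(C)c1ccc(NS(C)(=O)=O)c(F)c1`: 1.7 nM

These three compounds share one core and differ only in the group attached to one aromatic carbon. In an assay on cells for antagonist activity at transient receptor potential cation channel subfamily V member 1 (Homo sapiens), read by FLIPR and calcium flux, with a stated time of 6 min (on this read-out higher numbers stand for weaker inhibition and lower numbers for stronger inhibition), compound 3 gives 1.7 nM, the highest of the three numbers, but both a 1.4-fold higher number from compound 1 to compound 3 (0.15 log units; within the scatter) and a 1.9-fold higher number from compound 2 to compound 3 (0.28 log units; within the scatter) lie within the scatter, so no order among the three can be read from them. The exchange of one ring-nitrogen group for a larger one, a 1.3-fold lower number from compound 1 to compound 2 (0.12 log units; within the scatter), is likewise within the scatter.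

Compound 4, `CC(C(=O)NCc1ccc(C(C)(C)C)nc1OC1CCCCC1)c1ccc(NS(C)(=O)=O)c(F)c1`, has not yet been measured. It differs from compound 3 by cyclohexyl in place of propyl on an oxygen on an aromatic ring. For the measured compounds named here, no measured pair makes exactly this exchange. Going by the values given here, what bears on it is that every variation so far at this one aromatic carbon, whether a small ring, a larger ring or a propoxy group, left the number within the scatter, as a 1.3-fold lower number from compound 1 to compound 2 (0.12 log units; within the scatter), a 1.4-fold higher number from compound 1 to compound 3 (0.15 log units; within the scatter) and a 1.9-fold higher number from compound 2 to compound 3 (0.28 log units; within the scatter) show. Enlarging the group on the oxygen is therefore expected to give a step, a 1.1-fold lower number from compound 3 to compound 4 (0.05 log units; within the scatter), that stays within the scatter, in no clear direction. Compound 4 is estimated at 1.5 nM in this assay, with a range from 0.6 nM to 4 nM.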

Compound 4, inhibition constant: 2.5 nM
Beside the measured number, compound 4's estimate is 1.7-fold (0.22 log units) below it, within the range that was stated.
By their numbers in this assay, from the lowest: compounds 2, 1, 3 and 4 (each within the scatter of the next, the first and the last beyond it).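

In this assay, the first change made on the oxygen itself, propoxy to cyclohexyloxy, gives a 1.5-fold higher number from compound 3 to compound 4 (0.17 log units; within the scatter), so a six-membered carbon ring on the oxygen and the propyl chain cannot be told apart here. For the compounds shown here, what is new is that groups at this aromatic carbon can now be separated, if only modestly: cyclohexyloxy in place of the nitrogen-linked rings gives a 2.8-fold higher number from compound 2 to compound 4 (0.44 log units; beyond the scatter) and a 2.1-fold higher number from compound 1 to compound 4 (0.32 log units; beyond the scatter), the first steps in this set beyond the scatter, yet compound 3, also linked through oxygen, lies within the scatter of compound 1, compound 2 and compound 4, so it goes against any clean split between oxygen-linked and nitrogen-linked groups. No measurement is available that could explain these small differences.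

Still open, as far as these compounds go, is whether a much smaller or differently charged group at this aromatic carbon, such as a methoxy group, a primary amine or a carboxylic acid, would leave the number in the same range. From the compounds shown here alone, it is also open whether a ring on the oxygen that holds a nitrogen, such as piperidin-4-yl, would behave like cyclohexyl.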